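The source may hold more compounds than are shown below. What is called first, only, known or untested is meant among the compounds shown, and "the series" means these compounds.

In a functional assay on KYSE-450 cells (Homo sapiens) for inhibition, read by MTT assay, with a stated time of 48 h (a lower number here means a stronger inhibitor, a higher number a weaker inhibitor), compound 3 (`COc1ccc(CNc2cc(OC)c(OC)c(OC)c2)cc1C`) gives 73800 nM. Compound 1 (`COC(=O)c1cc(CNc2cc(OC)c(OC)c(OC)c2)ccc1OC`) gives 41100 nM, and the two sit together at the weak end of this small set, with a 1.8-fold higher number from compound 1 to compound 3 (0.25 log units; within the scatter). Compound 2 (`C/C=C/C(=O)N(Cc1ccc(OC)c(N)c1)c1cc(OC)c(OC)c(OC)c1`) stands far lower, at 310 nM.

Compound 4 (`COc1ccc(CNc2cc(OC)c(OC)c(OC)c2)cc1N`) has amino in place of methyl on an aromatic carbon, ortho to a methoxy group: amino in place of methyl on an aromatic carbon. Two measurements bear on this change, and neither settles it. Going by the values given here, the only measured step at this carbon is a 1.8-fold higher number from compound 1 to compound 3 (0.25 log units; within the scatter), which replaces methoxycarbonyl with methyl and stays small, but it says nothing directly about an amino group. Compound 2, at 310 nM, does carry the amino group, yet it also has a butenoyl group on the linking nitrogen. Among the compounds with values here, no measured step separates those two differences, so only part of its gap from compound 3 can be expected to carry over.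

A moderate move toward a lower number is therefore expected in this assay, with an estimated step of a 4.9-fold lower number from compound 3 to compound 4 (0.69 log units; beyond the scatter). The estimate for compound 4 is 15000 nM, with an expected range of 1500 nM to 80000 nM.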

Compound 4, half-maximal inhibitory concentration: 2210 nM
Estimate against measurement, compound 4: 6.8-fold (0.83 log units) above, within the range that was stated.
By their numbers in this assay, from the lowest: compound 2; then compound 4; then compounds 1 and 3 (each within the scatter of the next).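

In this assay, the amino group on this aromatic carbon, ortho to a methoxy group, makes a large difference on its own (a 33-fold lower number from compound 3 to compound 4 (1.52 log units; beyond the scatter)), and it also stands well apart from the methoxycarbonyl compound (a 19-fold lower number from compound 1 to compound 4 (1.27 log units; beyond the scatter)), whereas the earlier exchange of methoxycarbonyl for methyl at this carbon stayed within the scatter. The gap to compound 2 can now be divided, since hydrogen in place of (prop-1-en-1-yl)carbonyl on the linking nitrogen, with the amino group kept, gives a smaller, modest step (a 7.1-fold higher number from compound 2 to compound 4 (0.85 log units; beyond the scatter)), so both changes count, and the amino exchange is the larger of the two. Nothing measured here explains why the amino group has this effect.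

As far as these compounds go, whether a hydroxyl group or an acetamide on this carbon would match amino remains open, so it is unknown how specific the step is to amino itself. Also open, from the compounds shown here alone, is whether (prop-1-en-1-yl)carbonyl on the nitrogen would give a step of similar size with methyl on this carbon, and whether a longer acyl chain there would go further.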